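A few compounds are considered here, and "the series" means these few. Any claim that something is new, unique, unknown or untested is made for them only; others in the source may bear on it.

Measured so far in a functional assay on A549 cells (Homo sapiens) for antiproliferative activity, read by MTT assay, with a stated time of 48 h; on this read-out lower numbers stand for stronger inhibition and higher numbers for weaker inhibition:
- compound 1 `CCOC(=O)CN(Cc1ccccc1)c1nc(Nc2cccc(OC)c2)ncc1[N+](=O)[O-]`: compound 1 gives > 100000 nM, a limit of the assay rather than a number.
- compound 2 `CCOC(=O)CNc1nc(Nc2ccc(OC)cc2)ncc1[N+](=O)[O-]`: compound 2 gives > 100000 nM, likewise a limit.

Compound 2 thus stands at the limit itself, and both values shown sit there, as noted in the limit of > 100000 nM in this assay, at which 2 of the 2 values shown sit. Among the measured compounds shown here, no measured pair differing in one place exists, so no step has been read yet.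

Compound 3 `CCOC(=O)CNc1nc(Nc2cccc(OC)c2)ncc1[N+](=O)[O-]` differs from compound 2 in one place: 3-methoxyphenyl in place of 4-methoxyphenyl on a nitrogen on an aromatic ring. Compound 1 already carries the 3-methoxyphenyl on that nitrogen, together with a benzyl group elsewhere, and reaches only a limit in this assay. The shared core stays unchanged.

With both neighbours at the limit, no move beyond the scatter is expected. The step that the limit leaves unreadable from compound 2 to compound 3 is estimated as essentially none. Compound 3 is expected to give about 200000 nM, within 50000 nM to 1000000 nM, most likely again reported as a limit only.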

Compound 3, half-maximal inhibitory concentration: 36100 nM
Estimate against measurement, compound 3: 5.5-fold (0.74 log units) above; measured number outside the range, below it.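

In this assay, the placement of the methoxy group on the phenyl ring matters: 3-methoxyphenyl in place of 4-methoxyphenyl on a nitrogen on an aromatic ring gives an at least 2.7-fold lower number from compound 2 to compound 3 (0.44 log units; beyond the scatter). With 3-methoxyphenyl kept, the other nitrogen also matters, since hydrogen in place of benzyl gives an at least 2.7-fold lower number from compound 1 to compound 3 (0.44 log units; beyond the scatter), so the 3-methoxyphenyl group alone does not bring the number off the limit. Both steps are minimum sizes only, since compound 1 and compound 2 each give a limit rather than a number: the limit of > 100000 nM in this assay, at which 2 of the 3 values shown sit.

Going by these compounds, the true size of both steps remains open. On these data alone, it is also open whether a carboxylic acid or an amide in place of the ethyl ester, or a chloro or hydroxy group in place of the methoxy group, would lower the number further.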